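Amino substitution on two related fused cores: working notes

The source may report more compounds than this note shows. Statements on the series, on what has been measured and on what is new or still open speak of the compounds shown alone.

Compound 1, `Fc1cccc(F)c1C#Cc1cncc2ccccc12`, gives 87.9% in a functional assay on LS174T cells (Homo sapiens) for inhibition, with a stated time of 4 days, tested at 10 uM; a higher number here means a stronger effect of the compound at the concentration tested, a lower number a weaker effect. Compound 2, `Nc1ncc(C#Cc2c(F)cccc2F)c2ccccc12`, carries one change against compound 1, namely (amino in place of hydrogen on an aromatic carbon), and in this assay compound 2 gives 93.1%. The step that this change made is a number 5.2 percentage points higher from compound 1 to compound 2 (within the scatter). Compound 3, `Fc1cccc(F)c1C#Cc1cnc2ccccc2c1`, has the same atoms as compound 1 joined differently; the difference between the two cores is not broken down here. In this assay compound 3 gives 90.4%, and the numbers of compound 1, compound 2 and compound 3 all lie within the scatter of one another.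

Compound 4, `Nc1ccc2ncc(C#Cc3c(F)cccc3F)cc2c1`, is not yet measured. It differs from compound 3 by amino in place of hydrogen on an aromatic carbon. This is the same kind of change as that from compound 1 to compound 2, but the surroundings differ: in compound 2 the amino group sits on a six-membered aromatic ring with one nitrogen, next to the ring nitrogen, ortho to a fused ring, meta to a fused ring and para to a large group, whereas in compound 4 it sits on a six-membered aromatic ring of carbon only, meta to a fused ring and para to a fused ring.

Because a number 5.2 percentage points higher from compound 1 to compound 2 (within the scatter) stayed within the scatter, and because compound 3 already stands at 90.4% with little room upward, the step is expected to be a number 2.6 percentage points higher from compound 3 to compound 4 (within the scatter). In this assay compound 4 is expected to give about 93%, estimated between 84% and 98%.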

Compound 4, a percentage reported as inhibition, at one concentration (the size of the read-out at that concentration, not a potency): 9.2%
Compound 4: the middle estimate sits 83.8 percentage points above what was measured; the measured number lies below the stated range.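

Amino in place of hydrogen on an aromatic carbon does not carry over from one core to the other in this assay: the same change on two cores in this assay, a number 5.2 percentage points higher (within the scatter) from compound 1 to compound 2 and a number 81.2 percentage points lower (beyond the scatter) from compound 3 to compound 4, 86.4 percentage points apart, beyond the scatter of two such steps

On the core of compound 3 the change gives a number 81.2 percentage points lower from compound 3 to compound 4 (beyond the scatter), with the amino group on a six-membered aromatic ring of carbon only, meta to a fused ring and para to a fused ring, so a step read on one core in this series is no guide to the same change on the other. The two pairs differ both in the core and in where the amino group sits, and with a single pair per core the data neither separate these two factors nor say why the read-out falls; the read-out is also taken at one concentration and is not a potency.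

Open, from the compounds shown here alone, is whether the fall belongs to the amino group itself or to its place, a question that a hydroxyl, a methoxy or an acetamide at the same carbon of the core of compound 3, or the amino group on another carbon of that ring, would address. Also open, going by these compounds, is whether the core of compound 1 would hold its read-out with those same groups, or whether that result is confined to the amino group.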